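Oxadiazolylmethyl in place of the trifluoromethylcyclopentylmethyl group

The compounds below may be only part of what the source reports. "The series", "measured", "known", "first", "only" and "open" are said of these compounds alone.

Compound 3 `CS(=O)(=O)c1cnc(O[C@H]2CC[C@H](OC3CCN(CC4(C(F)(F)F)CCCC4)CC3)CC2)cn1` gives 48.8 nM in a functional assay on isolated protein for agonist activity at Glucose-dependent insulinotropic receptor (Homo sapiens), read by HTRF and cAMP accumulation (a lower number here means that less compound is needed, a higher number that more compound is needed for the effect), and sits at the high end of the three numbers seen so far. Its nearest neighbour is the amide compound 2 `CS(=O)(=O)c1cnc(O[C@H]2CC[C@H](OC3CCN(C(=O)C4(C(F)(F)F)CCCC4)CC3)CC2)cn1` with 38.4 nM; the step of a 1.3-fold higher number from compound 2 to compound 3 (0.10 log units; within the scatter) is within the scatter, so the two cannot be ordered. The carbamate compound 1 `CC(C)(C)OC(=O)N1CCC(O[C@H]2CC[C@H](Oc3cnc(S(C)(=O)=O)cn3)CC2)CC1` gives 5.9 nM, and the steps of a 6.5-fold higher number from compound 1 to compound 2 (0.81 log units; beyond the scatter) and an 8.3-fold higher number from compound 1 to compound 3 (0.92 log units; beyond the scatter) are both beyond the scatter.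

Compound 4 `CC(F)Cc1nc(CN2CCC(O[C@H]3CC[C@H](Oc4cnc(S(C)(=O)=O)cn4)CC3)CC2)no1` changes the group on the saturated chain carbon bound to the amine nitrogen in the ring: a group of 9 heavy atoms (5 carbon, 2 nitrogen, 1 oxygen, 1 fluorine; one five-membered aromatic ring with 3 hetero atoms) in place of a group of 9 heavy atoms (6 carbon, 3 fluorine; one five-membered non-aromatic ring of carbon only), on a saturated chain carbon bound to an amine nitrogen in a ring.

For the measured compounds named here, no measured step exchanges a carbocycle for a heteroaromatic ring, so there is no direct precedent. The steps from compound 1 show that the substituent on the piperidine nitrogen moves this assay by modest amounts, and the step from compound 2 to compound 3 shows that the link to that substituent matters little. An entering ring with three hydrogen-bond acceptors is more in the spirit of the carbamate of compound 1 than of the carbocycles, so a step of a 1.7-fold lower number from compound 3 to compound 4 (0.24 log units; within the scatter) toward the lower side is expected, though with wide uncertainty. Compound 4 is estimated at 28 nM in this assay, with a range of 7 nM to 110 nM.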

Compound 4, half-maximal effective concentration: 30.3 nM
Estimate against measurement, compound 4: 1.1-fold (0.03 log units) below; measured number inside the range.
By their numbers in this assay, from the lowest: compound 1; then compounds 4, 2 and 3 (each within the scatter of the next).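

In this assay, the step of a 1.6-fold lower number from compound 3 to compound 4 (0.21 log units; within the scatter) and the step of a 1.3-fold lower number from compound 2 to compound 4 (0.10 log units; within the scatter) both lie within the scatter, so compound 4 cannot be ordered against either compound 3 or compound 2. For the compounds shown here, on the saturated chain carbon bound to the amine nitrogen in the ring, a group with a five-membered aromatic ring and 3 hydrogen-bond acceptors is therefore not told apart from a carbocyclic group with 0 acceptors, which the earlier compounds could not show. The step of a 5.1-fold higher number from compound 1 to compound 4 (0.71 log units; beyond the scatter) lies beyond the scatter, so the entering acceptors do not place compound 4 with the carbamate compound 1, which keeps the lowest number of the four, and no measurement shown here accounts for this.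

Open, from the compounds shown here alone, is whether the fluorine of the 2-fluoropropyl chain has any bearing on the number, which a plain propyl or a tert-butyl on the same oxadiazole would test. Also open, going by these compounds, is whether a carbonyl link to the oxadiazole behaves like the methylene link of compound 4, as the link in compound 2 and compound 3 could not be told apart.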